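The compounds below may be only part of what the source reports. "The series", "measured", "known", "first", "only" and "open" are said of these compounds alone.

Measured so far in a functional assay on A549 cells (Homo sapiens) for cytotoxicity, read by sulforhodamine B assay, with a stated time of 3 days; on this read-out lower numbers stand for an effect already at smaller amounts and higher numbers for an effect only at larger amounts of compound:

- compound 1 `COC(=O)c1c(C)coc1-c1ccc2c(c1OC)CCCC2(C)C`: 61 uM
- compound 2 `Cc1coc(-c2ccc3c(c2O)CCCC3(C)C)c1C(=O)O`: 3.3 uM

Of these two compounds, compound 2 has the lower number at 3.3 uM, so it acts at smaller amounts. Compound 1 stands above it, by a gap beyond the usual scatter.

Compound 3 `COc1c(-c2occ(C)c2C(=O)O)ccc2c1CCCC2(C)C` has not yet been measured. It differs from compound 2 in one place: methyl in place of hydrogen on an oxygen on an aromatic ring, a methyl in place of hydrogen on an oxygen on an aromatic ring, or hydroxy to methoxy. Compound 1 also carries a methoxy and gives 61 uM, but it differs from compound 3 elsewhere too, so it is only a loose guide. Going by the values given here, no measured pair isolates this change. A moderate rise is therefore expected, and the estimated step is a 4.2-fold higher number from compound 2 to compound 3 (0.63 log units; beyond the scatter). In this assay, the estimate for compound 3 is 14 uM, with an expected range from 4 uM to 50 uM.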

Compound 3, concentration for half-maximal effect: 53.5 uM
Compound 3: middle estimate off by 3.8-fold (0.58 log units), on the low side, and the stated range ends below it.
By their numbers in this assay, from the lowest: compound 2; then compounds 3 and 1 (each within the scatter of the next).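

Taken alone, methyl in place of hydrogen on an oxygen on an aromatic ring is a large change in this assay and gives a 16-fold higher number from compound 2 to compound 3 (1.21 log units; beyond the scatter) with nothing else altered, which no earlier pair could show. With that methyl in place, the other change, hydrogen in place of methyl on an oxygen next to a carbonyl group, gives a 1.1-fold lower number from compound 1 to compound 3 (0.06 log units; within the scatter) and so leaves the two compounds indistinguishable. Nothing measured on these compounds bears on why the hydroxy to methoxy change has this effect.

Going by these compounds, it remains open whether only the hydrogen on this aromatic oxygen matters, or whether an ethoxy group or an amine at the same place would also give a high number. Also open, on these data alone, is how a methyl ester behaves when the hydroxy stays free, since the effect of the carbonyl-side methyl has been read only with the methoxy present.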